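Series notes: dihydroxyethyl for pyrrolidinylmethyl on compound 3

A few compounds are considered here, and "the series" means these few. Any claim that something is new, unique, unknown or untested is made for them only; others in the source may bear on it.

Measured so far:
- Compound 1 `Cn1ncc(Cl)c1-c1cc(C(=O)N[C@H]2CNCC[C@@H]2c2ccc(C(F)(F)F)cc2)oc1Cl`: in a functional assay on OVCAR-8 cells (Homo sapiens) for antiproliferative activity (on this read-out higher numbers stand for weaker inhibition and lower numbers for stronger inhibition), compound 1 gives 900 nM.
- Compound 2 `Cn1ncc(Cl)c1-c1cc(C(=O)N[C@@H]2CNCC[C@H]2c2ccc(C(F)(F)F)cc2)oc1Cl`: in this assay compound 2 gives 120 nM.
- Compound 3 `Cn1ncc(Cl)c1-c1cc(C(=O)N[C@@H]2CN[C@H](CCN3CCCC3)C[C@H]2c2ccc(Cl)c(Cl)c2)oc1Cl`: in this assay compound 3 gives 1840 nM.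

Compound 3 stands highest of the three numbers, the weakest inhibitor shown. Among the compounds with values here, the only one-place step measured is a 7.5-fold lower number from compound 1 to compound 2 (0.88 log units; beyond the scatter); it rests on the fact that compounds 1 and 2 differ only in the configuration as drawn and carries no information about exchanging a substituent on the saturated chain carbon.

Compound 4 `Cn1ncc(Cl)c1-c1cc(C(=O)N[C@@H]2CN[C@H](CC(O)CO)C[C@H]2c2ccc(Cl)c(Cl)c2)oc1Cl` differs from compound 3 by 1,2-dihydroxyethyl in place of (pyrrolidin-1-yl)methyl on a saturated chain carbon bound to a saturated ring carbon. Within the data shown here, no measured step bears on this change, so no shift beyond the scatter is expected in either direction. The estimate for compound 4 is 1800 nM, with a range from 500 nM to 6500 nM. This estimate corresponds to an expected step of a 1.0-fold lower number from compound 3 to compound 4 (0.01 log units; within the scatter), and the range is kept wide.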

Compound 4, half-maximal inhibitory concentration: 1610 nM
Compound 4: middle estimate off by 1.1-fold (0.05 log units), on the high side, within the range that was stated.
By their numbers in this assay, from the lowest: compound 2; then compounds 1, 4 and 3 (each within the scatter of the next, the first and the last beyond it).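

In this assay, 1,2-dihydroxyethyl in place of (pyrrolidin-1-yl)methyl on a saturated chain carbon bound to a saturated ring carbon gives a 1.1-fold lower number from compound 3 to compound 4 (0.06 log units; within the scatter) and so opens no gap between the two groups. At this place, a group with a five-membered non-aromatic ring and a group with no ring read alike, despite their different hydrogen-bond donor counts. Nothing in the data shown bears on why the two read alike.

On these data alone, whether a carboxylic acid, a primary amine or a longer chain at this place would shift the number beyond the scatter remains open.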